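A few compounds are considered here, and "the series" means these few. Any claim that something is new, unique, unknown or untested is made for them only; others in the source may bear on it.

In an ADME assay on HEK293 cells (Homo sapiens) for cytotoxicity, read by resazurin assay, with a stated time of 24 h (a higher number here means that more compound is tolerated, a lower number that less compound is tolerated), three compounds have been measured:

Compound 1 `O=C(O)c1c(O)cccc1C=Cc1ccc2ccccc2c1` gives 97000 nM.
Compound 2 `O=C(O)c1c(O)cccc1CCc1ccccc1` reaches only the limit of the assay, > 100000 nM, and no number.
Compound 3 `Cc1cc(O)c(C(=O)O)c(CCc2ccc3ccccc3c2)c1` gives 40000 nM.

Among the numbers shown, compound 1 stands highest of the two; its nearest neighbour is compound 3, whose number is lower by a margin beyond the usual scatter. The third value, that of compound 2, is a limit of > 100000 nM in this assay, at which 1 of the 3 values shown sits, and is not counted as a number here.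

Compound 4 `O=C(O)c1c(O)cc(Cl)cc1C=Cc1ccc2ccccc2c1` has not yet been measured in this assay. It differs from compound 1 in one place: chloro in place of hydrogen on an aromatic carbon. Among the compounds with values here, no step between measured compounds isolates this kind of change, so the expectation rests on the spread of the three values shown. Compound 4 is expected to sit somewhat below compound 1, with a step from compound 1 to compound 4 of a 1.8-fold lower number from compound 1 to compound 4 (0.25 log units; within the scatter), modest in size and downward. The estimate for compound 4 is 55000 nM, with a range from 20000 nM to 100000 nM.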

Compound 4, half-maximal cytotoxic concentration: 38000 nM
Beside the measured number, compound 4's estimate is 1.4-fold (0.16 log units) above it; measured number inside the range.
By their numbers in this assay, from the lowest: compounds 4 and 3 (each within the scatter of the next); then compound 1. At a limit, above all of these: compound 2.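

In this assay, within the data shown here, chloro in place of hydrogen on an aromatic carbon, para to a carboxy group and meta to a hydroxy group, gives a 2.6-fold lower number from compound 1 to compound 4 (0.41 log units; beyond the scatter) and so provides the first step here that isolates a single change. It shows that this position of the core of compound 1 is not silent: less compound is tolerated with chloro there, in a modest step that lies beyond the scatter. Nothing measured here bears on the cause of this step.

Whether the step is particular to chloro stays open, since the compounds shown include no fluoro, methoxy or amine at this position. Also open, from the compounds shown here alone, is whether the same change would give a similar step on a core other than that of compound 1.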